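Swapping a dichlorophenyl for a pyridine on the piperazine

The source may report more compounds than this note shows. Statements on the series, on what has been measured and on what is new or still open speak of the compounds shown alone.

Compound 3 `O=C([C@@H]1C[C@H](N2CCN(c3ccc(Cl)c(Cl)c3)CC2)CN1)N1CCSC1` gives 4.2 nM in an assay on a cell-free system (plasma) for inhibition of Dipeptidyl peptidase 4 (Rattus norvegicus), read by fluorescence (a higher number here means a weaker inhibitor, a lower number a stronger inhibitor), the second highest number among three measured compounds. Compound 1 `N#Cc1cccnc1N1CCN([C@@H]2CN[C@H](C(=O)N3CCSC3)C2)CC1` gives 1.2 nM, and compound 2 `COc1ccc(N2CCN([C@@H]3CN[C@H](C(=O)N4CCSC4)C3)CC2)cc1` gives 16.9 nM. Compound 4 `O=C([C@@H]1C[C@H](N2CCN(c3ccncc3)CC2)CN1)N1CCSC1` differs from compound 3 by pyridin-4-yl in place of 3,4-dichlorophenyl on an amine nitrogen in a ring. For the measured compounds named here, no measured step makes exactly this change; the nearest are a 3.5-fold higher number from compound 1 to compound 3 (0.54 log units; beyond the scatter) and a 4.0-fold lower number from compound 2 to compound 3 (0.60 log units; beyond the scatter), both modest, showing that this aromatic group shifts the number in either direction. A heteroaromatic ring, as in compound 1, went with the lowest number, but that ring also carried a nitrile. A modest rise is therefore expected, a 1.9-fold higher number from compound 3 to compound 4 (0.28 log units; within the scatter). Compound 4 is estimated at 8 nM, with a range of 2 nM to 35 nM.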

Compound 4, half-maximal inhibitory concentration: 3.9 nM
For compound 4 the middle estimate is 2.1-fold (0.31 log units) above the measured one; the range from low to high includes it.
By their numbers in this assay, from the lowest: compound 1; then compounds 4 and 3 (each within the scatter of the next); then compound 2.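

At this amine nitrogen, in this assay, pyridin-4-yl and 3,4-dichlorophenyl cannot be told apart (a 1.1-fold lower number from compound 3 to compound 4 (0.03 log units; within the scatter)), so the aromatic ring here need not be carbon-only or carry chlorine. Pyridin-4-yl stands clear of 4-methoxyphenyl (a 4.3-fold lower number from compound 2 to compound 4 (0.64 log units; beyond the scatter)). A pyridine ring without a nitrile also does not match 3-cyanopyridin-2-yl (a 3.3-fold higher number from compound 1 to compound 4 (0.51 log units; beyond the scatter)), though the point of attachment differs there too. No measurement shown gives a reason for these differences. As far as these compounds go, whether a nitrile, an amine or a carboxylic acid on pyridin-4-yl would move the number remains open.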